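A Benzoyl Group in Place of the Protected Glycine

This account rests on a few compounds, and the source may have more. Where it says the series, first, only, none or still open, it means among the compounds named here.

Compound 1 `COc1ccc(N(CC(=O)NCCC[Te]c2ccccc2)C(=O)CNC(=O)OC(C)(C)C)cc1` was tested in a functional assay on CAKI-1 cells (Homo sapiens) for inhibition, with a stated time of 48 h; on this read-out lower numbers stand for higher toxicity in this test and higher numbers for lower toxicity in this test. For compound 1 this assay reports only a limit, < 100000 nM. Compound 2 `COc1ccc(N(CC(=O)NCCC[Te]c2ccccc2)C(=O)CCSC2=C(C)C(=O)c3ccccc3C2=O)cc1` gives 21400 nM in this assay. Compound 3 `COc1ccc(N(CC(=O)NCCC[Te]c2ccccc2)C(=O)c2ccccc2)cc1` differs from compound 1 by phenyl in place of ((tert-butoxycarbonyl)amino)methyl on a carbonyl carbon. Among the compounds with values here, since compound 1 sits at the limit of < 100000 nM in this assay, at which 1 of the 2 values shown sits, no measured step is available as a yardstick. One expects the step that the limit leaves unreadable from compound 1 to compound 3 to stay within the usual scatter, or to bring only a modest gain in toxicity. Compound 3 is therefore estimated at 60000 nM, in the range 20000 nM to 150000 nM.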

Compound 3, concentration lethal to 50% of the cells: < 100000 nM
Compound 3: no number, only a limit (the forecaster's own chance of this, stated with the estimate: 55%); the middle value lies beyond the limit too.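

Within the data shown here, compound 1 and compound 3 both rest on limits, not numbers, so no step between them can be read: the limit of < 100000 nM in this assay, at which 2 of the 3 values shown sit.

On these data alone, whether phenyl in place of ((tert-butoxycarbonyl)amino)methyl changes toxicity in this test at all, and by how much, stays open.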